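The source may hold more compounds than are shown below. What is called first, only, known or untested is meant among the compounds shown, and "the series" means these compounds.

Series notes. The set holds three measured compounds and one awaiting measurement, all read in an assay on cells for inhibition of Amine oxidase [flavin-containing] B (Homo sapiens), read by fluorescence, with stated times of 30 min and 15 min, tested at 1 uM; a lower number here means less inhibition, a higher number more inhibition at the concentration tested (going by the name of the read-out). Compound 1 `COc1ccc(OCCOc2ccc3c(c2)C(=C(C)C)C(=O)N3)cc1` and compound 2 `CC1(C)C(=O)Nc2ccc(OCCOc3ccccc3)cc21` carry no number; in this assay compound 1 is recorded as "not active" (no number reported), and compound 2 likewise as "not active" (no number reported). Among the measured compounds shown here, compound 3 `CC(C)C1C(=O)Nc2ccc(OCc3cccc(F)c3)cc21` is the only member with a figure: in this assay compound 3 gives 12.7%. On the numbers shown, compound 3 therefore stands alone, with two further entries beside it that give no value at all, so no step between measured compounds can be drawn.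

Compound 4 `Cc1ccc(COc2ccc3c(c2)C(C(C)C)C(=O)N3)cc1` is the next entry to be measured in this assay. It differs from compound 3 in one place: 4-methylphenyl in place of 3-fluorophenyl on a saturated chain carbon bound to an oxygen on an aromatic ring. The rest of the shared core is untouched.

For the measured compounds named here, with no measured step to lean on, the expectation rests on compound 3 alone, whose value of 12.7% is small, and on the fact that the change keeps the same ring count and atom count. For compound 4 the step from compound 3 is expected to be a number 0.7 percentage points lower from compound 3 to compound 4 (within the scatter), that is, none beyond the usual scatter in either direction. Compound 4 is accordingly estimated at 12% in this assay, with a range from 0% to 28%, and a real chance that it is reported without a number, as compound 1 and compound 2 were.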

Compound 4, a percentage reported as inhibition, at one concentration (the size of the read-out at that concentration, not a potency): "not active" (no number reported)
Compound 4: no number reported, and the estimate cannot be compared.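

In this assay compound 3 gives 12.7% and compound 4 is recorded as "not active" (no number reported), so no step can be read from compound 3 to compound 4. No other data bear on this result. The compounds shown leave open how 4-methylphenyl compares numerically with 3-fluorophenyl in this assay.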